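The source may hold more compounds than are shown below. What is called first, only, known or untested is meant among the compounds shown, and "the series" means these compounds.

Working notes on the series. Three compounds have been run in an assay on HEK293 cells for displacement of a labelled ligand from metabotropic glutamate receptor 5 (Homo sapiens), with a stated time of 2 h; on this read-out higher numbers stand for weaker inhibition and lower numbers for stronger inhibition. Compound 1 `CC(C)NC(=O)c1ccc(C#Cc2ccccc2)nc1` gives 7100 nM, and compound 2 `CN1CCc2nc(C#Cc3ccc(Cl)cc3)ccc2C1=O` gives 6150 nM. Compound 3 `CC(C)N1CCc2nc(C#Cc3ccccc3)ccc2C1=O` gives 1280 nM, the lowest of the three numbers; its gap to compound 2 and its gap to compound 1 both lie beyond the usual scatter of repeated runs, so compound 3 stands as the strongest binder of the three on this read-out.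

The next compound, compound 4 `CC(C)N1CCc2nc(C#Cc3cccnc3)ccc2C1=O`, keeps the core of compound 3 and differs in one place: pyridin-3-yl in place of phenyl on a triple-bonded carbon. Among the measured compounds shown here, no measured pair in the set shows this kind of exchange, so there is no step to lean on. Since the other changes in the set are on different parts of the molecule, the expectation rests on compound 3 alone. The expected step is a 1.4-fold higher number from compound 3 to compound 4 (0.15 log units; within the scatter), a small move in the direction of weaker inhibition that may well stay within the scatter. For compound 4 the estimate in this assay is 1800 nM, with a range from 600 nM to 5500 nM.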

Compound 4, inhibition constant: 19600 nM
Estimate against measurement, compound 4: 11-fold (1.04 log units) below, outside the stated range (above it).
By their numbers in this assay, from the lowest: compound 3; then compounds 2 and 1 (each within the scatter of the next); then compound 4.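

On the triple-bonded carbon, pyridin-3-yl in place of phenyl gives a 15-fold higher number from compound 3 to compound 4 (1.19 log units; beyond the scatter) in this assay, a large move towards weaker inhibition. Among the compounds shown here, this is the first step at this place, and it shows that the place is sensitive to the ring: the exchange of one ring carbon for nitrogen, with the heavy-atom count unchanged, is enough to move the number well beyond the scatter. No data at hand bear on the reason for this step.

Still open, on these data alone, is whether the loss is particular to pyridin-3-yl, or whether pyridin-2-yl, pyridin-4-yl or a phenyl carrying fluorine or a methyl group on the same carbon would stay closer to compound 3. Also open, as far as these compounds go, is whether the same exchange gives a step of similar size when a group other than isopropyl sits on the core.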